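Amino for 4-hydroxyphenyl in the sulfonyl morpholine series

A few compounds are considered here, and "the series" means these few. Any claim that something is new, unique, unknown or untested is made for them only; others in the source may bear on it.

Measured in a functional assay on MCF7 cells (Homo sapiens) for cytotoxicity, read by sulforhodamine B assay, with a stated time of 24 h; on this read-out higher numbers stand for weaker inhibition and lower numbers for stronger inhibition:
- compound 1 `N=c1oc2ccccc2cc1C(=O)N/N=C1\C(=O)Nc2ccc(S(=O)(=O)N3CCOCC3)cc21`: 20800 nM
- compound 2 `O=C1Nc2ccc(S(=O)(=O)N3CCOCC3)cc2/C1=N/c1ccc(O)cc1`: 52700 nM
- compound 3 `COc1ccc(-c2c(C#N)c(N)n(/N=C3\C(=O)Nc4ccc(S(=O)(=O)N5CCOCC5)cc43)c(=O)c2C#N)cc1`: 33400 nM

The number of compound 2 lies within the scatter of that of compound 3, and above that of compound 1 by a gap beyond the scatter. Compound 4 `N/N=C1\C(=O)Nc2ccc(S(=O)(=O)N3CCOCC3)cc21` has amino in place of 4-hydroxyphenyl on a double-bonded nitrogen. Within the data shown here, no measured pair isolates this change, so the expectation rests only on the narrow spread of the three values. In this assay the expected 1.3-fold lower number from compound 2 to compound 4 (0.12 log units; within the scatter) is a small move towards a lower number, within the scatter. For compound 4 the estimated value is 40000 nM, with an expected range of 15000 nM to 100000 nM.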

Compound 4, half-maximal inhibitory concentration: 46800 nM
Beside the measured number, compound 4's estimate is 1.2-fold (0.07 log units) below it; the measured number falls inside the stated range.
By their numbers in this assay, from the lowest: compounds 1, 3, 4 and 2 (each within the scatter of the next, the first and the last beyond it).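

In this assay, among these compounds, amino in place of 4-hydroxyphenyl on a double-bonded nitrogen gives a 1.1-fold lower number from compound 2 to compound 4 (0.05 log units; within the scatter), the first step that isolates this position. The aromatic ring can therefore go from this place with the two numbers remaining within the scatter of each other. Nothing at hand accounts for this result.

Still open, from the compounds shown here alone, is whether a larger replacement on this nitrogen, such as a 4-methoxyphenyl or a benzylidene group, would separate from these two numbers. Equally open, going by these compounds, is whether a carboxylic acid on the aromatic ring would do so.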